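Removing the trifluoromethyl group from the core of compound 1

The source may report more compounds than this note shows. Statements on the series, on what has been measured and on what is new or still open speak of the compounds shown alone.

Measured compounds:
compound 1, `O=[N+]([O-])c1ccccc1CNc1cc(C(F)(F)F)cc2[nH]ncc12`, 95%
compound 2, `O=[N+]([O-])c1ccc(Cl)cc1CNc1cc(C(F)(F)F)cc2[nH]ncc12`, 88%
compound 3, `O=[N+]([O-])c1cc(OCc2ccccc2)ccc1CNc1cc(C(F)(F)F)cc2[nH]ncc12`, 55%

In an assay for inhibition of Tryptophan 2,3-dioxygenase (Homo sapiens), with stated times of 10 min and 60 min, tested at 100 uM (on this read-out higher numbers stand for a stronger effect at the one concentration tested and lower numbers for a weaker effect), compound 1 gives 95%, the highest of the three numbers shown. Compound 2 is nearest to it, with a step of a number 7 percentage points lower from compound 1 to compound 2 (within the scatter), so the two cannot be told apart. Compound 3 stands furthest away, with a step of a number 40 percentage points lower from compound 1 to compound 3 (beyond the scatter).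

Compound 4, `O=[N+]([O-])c1ccccc1CNc1cccc2[nH]ncc12`, has not yet been measured in this assay. It differs from compound 1 by hydrogen in place of trifluoromethyl on an aromatic carbon. Within the data shown here, both measured steps change the ring that carries the nitro group, and neither touches the trifluoromethyl group on the shared core; no measured step therefore bears directly on this change. All that the numbers show is that the core of compound 1 tolerates small changes elsewhere but not every larger one.

With nothing to anchor the change, compound 4 is estimated to keep much of the inhibition of compound 1, but the estimated step of a number 25 percentage points lower from compound 1 to compound 4 (beyond the scatter) carries a wide range. The estimate for compound 4 is 70%, expected to lie between 35% and 95%.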

Compound 4, a percentage reported as inhibition, at one concentration (the size of the read-out at that concentration, not a potency): 87%
Compound 4: the middle estimate sits 17 percentage points below what was measured; measured number inside the range.
By their numbers in this assay, from the lowest: compound 3; then compounds 4, 2 and 1 (each within the scatter of the next).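

Taking the trifluoromethyl group off the shared core and leaving hydrogen on that aromatic carbon gives, in this assay, a step of a number 8 percentage points lower from compound 1 to compound 4 (within the scatter) and so the two compounds cannot be told apart. Among these compounds, this is the first reading at this position, as the earlier steps all changed the ring that carries the nitro group, and it shows that the core can lose this group of 4 heavy atoms with no difference that this read-out can resolve. The read-out comes from one concentration and is not a potency, so this says only that inhibition at that concentration stays within the scatter, and nothing shown here offers an explanation for the outcome.

As far as these compounds go, whether this aromatic carbon accepts anything other than hydrogen and trifluoromethyl stays open, and a methoxy group, an amine or a carboxylic acid there could go either way. Also open is whether the compound with hydrogen on the core responds to chloro and benzyloxy on the nitro-bearing ring as compound 1 does, as those two groups are shown only alongside trifluoromethyl.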